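The compounds below may be only part of what the source reports. "The series", "measured", "known", "first", "only" and "open" are said of these compounds alone.

Compound 1 `O=C(Nc1cccc(-n2cc(-c3ccncc3)c(-c3ccc(Cl)c(O)c3)n2)c1)Nc1cccc(C(F)(F)F)c1` gives 1570 nM in a functional assay on OVCAR-8 cells (Homo sapiens) for inhibition, read by sulforhodamine B assay, with a stated time of 48 h; on this read-out lower numbers stand for stronger inhibition of growth and higher numbers for weaker inhibition of growth.
Compound 2 `COc1cc(-c2nn(-c3cccc(NC(=O)Nc4cc(C(F)(F)F)cc(C(F)(F)F)c4)c3)cc2-c2ccncc2)ccc1Cl` gives 524 nM in this assay.

Of the two measured compounds, compound 1 carries the higher number, so on this read-out it is the weaker growth inhibitor of the pair; compound 2 sits at a lower number, a gap that is beyond the usual scatter. Compound 2 differs from compound 1 in more than one place, so its value shows only where it stands, not what any single change does.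

Compound 3 `O=C(Nc1cccc(-n2cc(-c3ccncc3)c(-c3ccc(Cl)c(O)c3)n2)c1)Nc1ccc(Cl)c(Cl)c1` is not yet measured. It differs from compound 1 in one place: 3,4-dichlorophenyl in place of 3-(trifluoromethyl)phenyl on an amide-type nitrogen. The shared core, the urea linkage and everything on the other side of it are unchanged. Within the data shown here, no measured pair in this set isolates such a swap, so there is no step to lean on. Both groups are aryl rings bearing halogen-type substituents and neither brings donors or acceptors, so the expectation is a step of no size beyond the scatter, in either direction, from compound 1 to compound 3, expressed as a 1.2-fold lower number from compound 1 to compound 3 (0.08 log units; within the scatter). Compound 3 is therefore estimated at 1300 nM, with a range from 400 nM to 4500 nM.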

Compound 3, concentration for 50% growth inhibition: 1210 nM
Beside the measured number, compound 3's estimate is 1.1-fold (0.03 log units) above it; the range from low to high includes it.
By their numbers in this assay, from the lowest: compound 2; then compounds 3 and 1 (each within the scatter of the next).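

In this assay, among these compounds, 3,4-dichlorophenyl in place of 3-(trifluoromethyl)phenyl on the amide-type nitrogen gives a 1.3-fold lower number from compound 1 to compound 3 (0.11 log units; within the scatter), which is the first reading in this set of a change made at one place alone. The two rings therefore cannot be told apart in this assay, even though their substituents differ, so on this single pair the position accepts either ring without a change in growth inhibition that stands clear of the scatter. Nothing measured here speaks to why the two rings read alike.

On these data alone, both rings are aromatic and carry only chlorine or trifluoromethyl, so it stays open how the position would respond to a ring bearing an amine or a carboxylic acid, or to a saturated ring such as cyclohexyl in place of the aromatic one. As far as these compounds go, it is also open whether this same swap would read alike on a different core, since a single pair cannot show whether the result holds beyond compound 1 and compound 3.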